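Working notes: compound 2 to compound 3

The compounds below may be only part of what the source reports. "The series", "measured", "known", "first", "only" and "open" are said of these compounds alone.

Compound 1 `CC(=O)Nc1nccc2ncc(-c3cnn(C)c3)cc12` gives > 50000 nM in a functional assay on HeLa cells (Homo sapiens) for antiproliferative activity, read by MTT assay, with a stated time of 48 h (on this read-out higher numbers stand for weaker inhibition and lower numbers for stronger inhibition), as a limit of the assay and not a number. For the measured compounds named here, compound 2 `Cn1cc(-c2cnc3ccnc(NCC4CC4)c3c2)cn1` gives 7400 nM in this assay and so holds the only true number so far. Going by the values given here, the one measured step is an at least 6.7-fold lower number from compound 1 to compound 2 (0.82 log units; beyond the scatter) and it rests on the limit of > 50000 nM in this assay, at which 1 of the 2 values shown sits, so its full size stays open. Compound 3 `COc1ccc(CNc2nccc3ncc(-c4cnn(C)c4)cc23)cc1` differs from compound 2 by 4-methoxyphenyl in place of cyclopropyl on a saturated chain carbon bound to a nitrogen on an aromatic ring and this puts 4-methoxyphenyl in place of cyclopropyl on a saturated chain carbon bound to a nitrogen on an aromatic ring. Among the compounds with values here, the measured step changed the group on that same nitrogen, but no measured step tests this swap, so it bears only loosely. With compound 2 at 7400 nM as the only anchor, the expected step is a 2.5-fold lower number from compound 2 to compound 3 (0.39 log units; beyond the scatter) in this assay and it is a modest one toward lower numbers, loosely held. For compound 3 the estimated value is 3000 nM with an expected range from 800 nM to 12000 nM in this series.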

Compound 3, half-maximal inhibitory concentration: 42200 nM
Compound 3: middle estimate off by 14-fold (1.15 log units), on the low side; measured number outside the range, above it.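

In this assay, the group on the saturated chain carbon bound to a nitrogen on an aromatic ring proves to matter in its own right: 4-methoxyphenyl in place of cyclopropyl gives a 5.7-fold higher number from compound 2 to compound 3 (0.76 log units; beyond the scatter). The earlier step changed the whole group on that nitrogen, whereas this one keeps the chain carbon and shows that the larger aromatic group lies on the weaker side, leaving compound 2 the strongest of the compounds shown. Compound 1 remains a limit and not a number: the limit of > 50000 nM in this assay, at which 1 of the 3 values shown sits.

The swap changes ring size, ring type and the oxygen together, and the compounds shown do not separate these. From the compounds shown here alone, how an unsubstituted phenyl, a cyclobutyl or a longer chain at this place would read, and whether any would fall below compound 2, stays open.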